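The source may hold more compounds than are shown below. What is called first, only, known or untested is meant among the compounds shown, and "the series" means these compounds.

Measured compounds in a functional assay on A549 cells (Homo sapiens) for cytotoxicity, read by MTT assay, with a stated time of 72 h; on this read-out lower numbers stand for stronger inhibition and higher numbers for weaker inhibition:
Compound 1, `O=C(Nc1ccc(Oc2ccnc3[nH]ccc23)cc1)c1nn(-c2ccc(Cl)cc2)ccc1=O`: 25100 nM.
Compound 2, `O=C(Nc1ccc(Oc2ccnc3[nH]ccc23)cc1)c1nn(-c2ccc(Cl)c(F)c2)ccc1=O`: 2580 nM.
Compound 3, `Cc1cc(=O)n(-c2ccc(F)cc2)nc1C(=O)Nc1ccc(Oc2ncnc3[nH]ccc23)cc1`: > 60000 nM, which is a limit of the assay and not a number.

Compound 4, `Cc1cc(=O)n(-c2ccc(F)cc2)nc1C(=O)Nc1ccc(Oc2ncnc3[nH]ccc23)c(F)c1`, has not yet been measured in this assay. It differs from compound 3 by fluoro in place of hydrogen on an aromatic carbon. The same kind of change separates compound 1 from compound 2, (fluoro in place of hydrogen on an aromatic carbon), though there the fluoro enters ortho to a chloro group, whereas in compound 4 it enters ortho to a large group, so the surroundings of the change are not the same. In this assay that earlier step gave a 9.7-fold lower number from compound 1 to compound 2 (0.99 log units; beyond the scatter). The difference between the core of compound 1 and the core of compound 3 is not broken down here. For compound 4 the account expects an at least 1.7-fold lower number from compound 3 to compound 4 (0.23 log units; that floor lies within the scatter), a more cautious step than the earlier one, because compound 3 sits at the limit of > 60000 nM in this assay, at which 1 of the 3 values shown sits, and the starting point of the step is itself unknown. Compound 4 is therefore estimated at 35000 nM, with a range from 8000 nM to 60000 nM.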

Compound 4, half-maximal inhibitory concentration: 42400 nM
For compound 4 the middle estimate is 1.2-fold (0.08 log units) below the measured one, within the range that was stated.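

In this assay, fluoro in place of hydrogen on an aromatic carbon gives an at least 1.4-fold lower number from compound 3 to compound 4 (0.15 log units; that floor lies within the scatter). Compound 3 gives > 60000 nM, which is a limit of the assay and not a number. The number falls on both cores, but this does not show whether the size of the step carries from one core to the other: the same change on two cores in this assay, a 9.7-fold lower number (0.99 log units; beyond the scatter) from compound 1 to compound 2 and an at least 1.4-fold lower number (0.15 log units; that floor lies within the scatter) from compound 3 to compound 4; the limit leaves it open whether they differ

The compounds shown leave open whether a methoxy group or an amine in the place taken by the fluoro in compound 4 would change the number. They also leave open how the same change would behave on a core whose parent compound gives a value that is not a limit.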